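The compounds below may be only part of what the source reports. "The series", "measured", "known", "first", "only" and "open" are said of these compounds alone.

Values in a physicochemical assay for lipophilicity, at pH 7.4; on this read-out higher numbers stand for higher lipophilicity and lower numbers for lower lipophilicity:
- compound 1 `Cc1cc(C(=O)Nc2ccc(F)cc2)nn1Cc1cc(Cl)ccc1OCc1ccccc1`: 3
- compound 2 `Cc1cc(C(=O)Nc2c(F)cccc2F)nn1Cc1cc(Cl)ccc1OCc1ccccc1`: 3.7
- compound 3 `Cc1cc(NC(=O)CC(C)(C)C)nn1Cc1cc(Cl)ccc1OCc1ccccc1`: > 3.7 (a limit, not a number)

For compound 3 the reading > 3.7 is a limit of this assay and not a number.

Compound 4 `Cc1cc(NC(=O)C2CCCC2)nn1Cc1cc(Cl)ccc1OCc1ccccc1` differs from compound 3 in one place, with cyclopentyl in place of neopentyl on a carbonyl carbon.

Among the compounds with values here, no measured step makes this exchange, so the evidence is indirect. Within the data shown here, two steps replace the whole carbamoyl group of the earlier compounds: a number at least 0.70 log units higher from compound 1 to compound 3 (beyond the scatter) and a number no lower from compound 2 to compound 3 (the limit leaves the size open). Among the measured compounds shown here, the only step with a fully readable size is a number 0.70 log units higher from compound 1 to compound 2 (beyond the scatter), and it concerns 2,6-difluorophenyl in place of 4-fluorophenyl, which is a different kind of change.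

The amide link stays in place in compound 4, and the entering and leaving groups differ mainly by the ring, so no change beyond the scatter is expected. The expected step is a number no higher from compound 3 to compound 4 (the limit leaves the size open). For the measured compounds named here, this expectation leans on a number no lower from compound 2 to compound 3 (the limit leaves the size open), which gives the only anchor for compound 3.

Compound 4 is estimated at 3.7, with an expected range from 3.2 to 4.2. A limit reading instead of a number is also a real possibility.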

Compound 4, distribution coefficient: 3.5
Compound 4: middle estimate off by 0.20 log units, on the high side; the range from low to high includes it.
By their numbers in this assay, from the lowest: compound 1; then compounds 4 and 2 (each within the scatter of the next).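

In this assay compound 4 gives 3.5, which is a readable number for a compound with an acylamino group on this aromatic carbon. Compound 3, the earlier compound of that type, gave only a limit. Against the carbamoyl compounds, the picture divides: there is a number 0.50 log units higher from compound 1 to compound 4 (beyond the scatter), yet a number 0.20 log units lower from compound 2 to compound 4 (within the scatter), so the (cyclopentylcarbonyl)amino group can be told apart from the (4-fluorophenyl)carbamoyl group but not from the (2,6-difluorophenyl)carbamoyl group. Within the data shown here, on the carbonyl carbon itself, cyclopentyl in place of neopentyl gives a number at least 0.20 log units lower from compound 3 to compound 4 (that floor lies within the scatter), the first direct look at a change confined to this group, where the ring comes in with the carbon count unchanged.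

The true size of that step stays open because compound 3 holds a limit and not a number: the limit of > 3.7 in this assay, at which 1 of the 4 values shown sits.

How an amine, a carboxylic acid or a longer chain on this carbonyl carbon would read in this assay also remains open, since the compounds shown carry only neopentyl and cyclopentyl there.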